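This account rests on a few compounds, and the source may have more. Where it says the series, first, only, none or still open, it means among the compounds named here.

Compound 1 `Cc1nc(-c2c(F)cccc2-c2cnc([C@@H](C)NC(=O)N(C)O)c(F)c2)no1`: 31 nM
Compound 2 `Cc1nc(-c2c(F)cc(Cl)cc2-c2ccc(CNC(=O)N(C)O)c(F)c2)no1`: 32 nM
Compound 3 `CC(C)N(O)C(=O)NCc1ncc(-c2cc(Cl)cc(F)c2-c2nnn(C)n2)cc1F`: 1 nM

These three compounds were tested in a functional assay on IMR-90 cells for antagonist activity at B1 bradykinin receptor (Homo sapiens), read by calcium flux; a lower number here means a stronger inhibitor, a higher number a weaker inhibitor. Among them compound 3 has the lowest number, and its separation from compound 1 and from compound 2 is beyond the usual scatter of the measurement, so compound 3 is the strongest inhibitor of the three. Compound 1 and compound 2 give numbers close to each other.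

Compound 4 `Cn1nnc(-c2c(F)cc(Cl)cc2-c2cnc(CNC(=O)N(O)C3CCC(F)(F)CC3)c(F)c2)n1` is the next compound and has not yet been measured in this assay. It differs from compound 3 in one place: 4,4-difluorocyclohexyl in place of isopropyl on an amide-type nitrogen. Within the data shown here, no pair of measured compounds shows what this particular swap does, so the size of the step is an open question. The expectation is a small step, from compound 3 to compound 4, of a 2.0-fold higher number from compound 3 to compound 4 (0.30 log units; within the scatter), most likely towards a somewhat higher number but possibly none beyond the scatter. For compound 4 the estimated value in this assay is 2 nM, expected to fall between 0.5 nM and 8 nM.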

Compound 4, half-maximal inhibitory concentration: 0.19 nM
Compound 4: the middle estimate sits 11-fold (1.02 log units) above what was measured; measured number outside the range, below it.
By their numbers in this assay, from the lowest: compound 4; then compound 3; then compounds 1 and 2 (each within the scatter of the next).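

In this assay, putting 4,4-difluorocyclohexyl in place of isopropyl on the amide-type nitrogen gives a 5.3-fold lower number from compound 3 to compound 4 (0.72 log units; beyond the scatter), the first step among these compounds that changes only one place. This nitrogen therefore accepts a group with a six-membered non-aromatic ring of carbon only, with more heavy atoms than isopropyl, and inhibition grows stronger rather than weaker. Nothing measured here explains the gain.

Going by these compounds, whether the ring or its two fluorine atoms carry the step stays open, and plain cyclohexyl, a smaller cyclobutyl ring or a longer chain such as n-butyl on this nitrogen would help to separate them. Also open, on these data alone, is whether the same swap would give a similar step on the core of compound 1 or compound 2.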